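Adding Bromo to the Core of Compound 2

A few compounds are considered here, and "the series" means these few. Any claim that something is new, unique, unknown or untested is made for them only; others in the source may bear on it.

Measured in a functional assay on SK-OV-3 cells (Homo sapiens); on this read-out lower numbers stand for stronger inhibition of growth and higher numbers for weaker inhibition of growth:
- Compound 1 `O=S(=O)(/C=C/c1ccccc1)Cc1ccc(Nc2ncnc3ccccc23)cc1`: 5000 nM
- Compound 2 `O=S(=O)(/C=C/c1ccc(Cl)cc1Cl)Cc1ccc(Nc2ncnc3ccccc23)cc1`: 2000 nM
- Compound 3 `O=S(=O)(/C=C/c1ccc(F)cc1Cl)Cc1ccc(Nc2ncnc3ccccc23)cc1`: 44000 nM

Compound 2 has the lowest number of the three, making it the strongest growth inhibitor so far. Compound 4 `O=S(=O)(/C=C/c1ccc(Cl)cc1Cl)Cc1ccc(Nc2ncnc3ccc(Br)cc23)cc1` keeps all of compound 2 except for one change on the shared core: bromo in place of hydrogen on an aromatic carbon. For the measured compounds named here, no measured step touches the core, so the evidence is only indirect. All three steps alter the phenyl group on the double-bonded chain instead. They run a 2.5-fold lower number from compound 1 to compound 2 (0.40 log units; beyond the scatter), an 8.8-fold higher number from compound 1 to compound 3 (0.94 log units; beyond the scatter) and a 22-fold higher number from compound 2 to compound 3 (1.34 log units; beyond the scatter). Small swaps in this series can therefore matter, and they can push the number either way. From the compounds shown here alone, these steps give no direction for a new bromo on the core, so no step beyond the scatter is expected in this assay, though a wide range must stay open. The expected step is a 1.3-fold lower number from compound 2 to compound 4 (0.10 log units; within the scatter). For compound 4 the estimated value is 1600 nM, with an expected range from 300 nM to 10000 nM.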

Compound 4, concentration for 50% growth inhibition: 1000 nM
Estimate against measurement, compound 4: 1.6-fold (0.20 log units) above; low and high end bracket the measured number.
By their numbers in this assay, from the lowest: compounds 4 and 2 (each within the scatter of the next); then compound 1; then compound 3.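

For the compounds shown here, this is the first step that touches the shared core, and in this assay bromo in place of hydrogen gives a 2.0-fold lower number from compound 2 to compound 4 (0.30 log units; within the scatter). This aromatic carbon therefore accepts a bromine atom without a change that can be told from assay scatter, whereas one swap on the phenyl group gives a 22-fold higher number from compound 2 to compound 3 (1.34 log units; beyond the scatter). Nothing in the available data explains why these two changes differ so much in size.

From the compounds shown here alone, whether a different group on this same aromatic carbon, such as a methoxy or an amine, would also stay within the scatter remains open. It is also unknown whether bromo would give a similar result on compound 1 or compound 3, which carry different phenyl groups on the double-bonded chain.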